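Working notes: aryl chloro removal in the shared peroxide series

This account rests on a few compounds, and the source may have more. Where it says the series, first, only, none or still open, it means among the compounds named here.

Measured compounds:
compound 1, `C=C(c1ccc(Cl)c(Cl)c1Cl)C1COC2(CCCC2)OO1`, 11500 nM
compound 2, `C=C(c1ccc(Cl)c(Cl)c1)C1COC2(CCCC2)OO1`, 50900 nM
compound 3, `C=C(c1ccc(Cl)c(Cl)c1Cl)C1COC2(CCCCC2)OO1`, 10300 nM

The read-out throughout is a functional assay on BEAS-2B cells (Homo sapiens) for inhibition, read by MTT assay, with a stated time of 72 h; on this read-out higher numbers stand for weaker inhibition and lower numbers for stronger inhibition. Compound 1 gives 11500 nM, and removing one chloro from its aromatic ring, (hydrogen in place of chloro on an aromatic carbon), gives compound 2 with 50900 nM; the step of a 4.4-fold higher number from compound 1 to compound 2 (0.65 log units; beyond the scatter). Compound 3 carries the same trichlorinated aromatic ring on a different core and gives 10300 nM, a number within the scatter of that of compound 1; the difference between the two cores is not broken down here. Compound 2 sits beyond the scatter of both compound 1 and compound 3.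

Compound 4, `C=C(c1ccc(Cl)cc1Cl)C1COC2(CCCCC2)OO1`, is not yet measured. It derives from compound 3 by hydrogen in place of chloro on an aromatic carbon. This is the same kind of change as that from compound 1 to compound 2, but not the same: in compound 1 the leaving chloro is ortho to a chloro group, ortho to a large group and meta to a chloro group, whereas in compound 3 it is ortho to two chloro groups and meta to a large group. Within the data shown here, the expectation for the step of a 3.4-fold higher number from compound 3 to compound 4 (0.53 log units; beyond the scatter) is that it resembles in direction and size the step of a 4.4-fold higher number from compound 1 to compound 2 (0.65 log units; beyond the scatter), since that is the only precedent for a chloro-to-hydrogen change in this set. On that basis compound 4 is estimated at 35000 nM, with a likely range from 14000 nM to 90000 nM.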

Compound 4, half-maximal inhibitory concentration: 16700 nM
Compound 4: the middle estimate sits 2.1-fold (0.32 log units) above what was measured; the range from low to high includes it.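

In this assay, hydrogen in place of chloro on an aromatic carbon does not carry over at one size between these two cores: the same change on two cores in this assay, a 4.4-fold higher number (0.65 log units; beyond the scatter) from compound 1 to compound 2 and a 1.6-fold higher number (0.21 log units; within the scatter) from compound 3 to compound 4, 2.7-fold (0.44 log units) apart, beyond the scatter of two such steps. The new step is a 1.6-fold higher number from compound 3 to compound 4 (0.21 log units; within the scatter), so this removal stays within the scatter on the core of compound 3, whereas the earlier step on the core of compound 1 does not, and a step measured on one core therefore does not serve as a reliable estimate for the other. Among these compounds, this does not show that the core alone sets the size of the step, since the chloro that leaves from compound 3 sits ortho to two chloro groups and meta to a large group and is not at the same place as the one that leaves from compound 1, so core and place vary together in this pair of steps, and two steps give no general rule for the series.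

Still open, as far as these compounds go, is whether the size of the step follows the core or the place, which would need each of these two chloro groups taken away on the other core. Also open, from the compounds shown here alone, is how a group other than hydrogen, such as fluoro, methoxy or an amine, would read at the same aromatic carbon on either core.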